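Amine variation on a shared core: compounds 1 to 4

This account rests on a few compounds, and the source may have more. Where it says the series, first, only, none or still open, it means among the compounds named here.

Measured so far in a functional assay on ECa-109 cells (Homo sapiens) for cytotoxicity, read by MTT assay, with a stated time of 72 h; a higher number here means a weaker inhibitor, a lower number a stronger inhibitor:
- compound 1 `Cc1cc(N2CCCCC2)nc(SCc2nc3ccccc3[nH]2)n1` gives > 100000 nM, a limit of the assay.
- compound 2 `Cc1cc(NCCO)nc(SCc2nc3ccccc3[nH]2)n1` gives > 100000 nM, a limit of the assay.
- compound 3 `Cc1cc(NNC(N)=S)nc(SCc2nc3ccccc3[nH]2)n1` gives > 100000 nM, a limit of the assay.

Compound 3 therefore stands at the limit, and the two other values are limits as well (the limit of > 100000 nM in this assay, at which 3 of the 3 values shown sit). The steps between the measured compounds, a step that the two limits leave unreadable from compound 1 to compound 2, a step that the two limits leave unreadable from compound 1 to compound 3 and a step that the two limits leave unreadable from compound 2 to compound 3, are consequently unreadable in size and direction.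

Compound 4 `Cc1cc(N(C)Cc2ccccc2)nc(SCc2nc3ccccc3[nH]2)n1` is not yet measured. It differs from compound 3 as follows: a group of 9 heavy atoms (8 carbon, 1 nitrogen; one six-membered aromatic ring of carbon only) in place of a group of 5 heavy atoms (1 carbon, 3 nitrogen, 1 sulfur; no ring), on an aromatic carbon. Among the measured compounds shown here, no measured step bears on this change in a readable way, since all three measured compounds sit at the limit. The only expectation the data support is that compound 4 will also sit at or near the limit; the step of a number no higher from compound 3 to compound 4 (the limit leaves the size open) is estimated only, not inferred. Compound 4 is expected to give about 100000 nM in this assay, within 20000 nM to 400000 nM, most likely reported as a limit again.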

Compound 4, half-maximal inhibitory concentration: > 100000 nM
Compound 4: only a limit was reported; the forecaster's own chance of this, stated with the estimate: 70%; the middle value lies on the limit itself.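

In this assay compound 4 gives > 100000 nM, which is a limit. Among the compounds shown here, no step from compound 1, compound 2 or compound 3 to compound 4 can be read: the limit of > 100000 nM in this assay, at which 4 of the 4 values shown sit. The compounds shown leave open which amine group on the shared core, if any, gives a value short of that limit.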